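From propyl to cyclohexyl on the shared core

The compounds below may be only part of what the source reports. "The series", "measured", "known", "first", "only" and "open" are said of these compounds alone.

Compound 1 `c1ccc(COC[C@H]2OCC[C@@H](OCc3ccccc3)[C@@H]2OCc2ccccc2)cc1` gives 22200 nM
Compound 2 `CC[C@@H]1O[C@H](COCc2ccccc2)[C@@H](OCc2ccccc2)[C@H](OCc2ccccc2)[C@H]1OC(C)=O` gives > 50000 nM (a limit of the assay, not a number)
Compound 3 `CCCC[C@@H]1O[C@H](COCc2ccccc2)[C@@H](OCc2ccccc2)[C@H](OCc2ccccc2)[C@H]1O` gives 40100 nM

These three results come from a functional assay on HOS cells (Homo sapiens) for antiproliferative activity, read by sulforhodamine B assay (a lower number here means a stronger inhibitor of growth, a higher number a weaker inhibitor of growth), and describe weak growth inhibition. Compound 3 (at 40100 nM) lies within the scatter of compound 1 (at 22200 nM), so no order can be drawn between them. Compound 2 has only a limit, with no number to place beside the others.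

The next compound is compound 4 `O[C@@H]1[C@@H](OCc2ccccc2)[C@H](OCc2ccccc2)[C@@H](COCc2ccccc2)O[C@H]1CC1CCCCC1`, which carries cyclohexyl in place of propyl on a saturated chain carbon bound to a saturated ring carbon (the same difference reads butyl to cyclohexylmethyl). Among the compounds with values here, no measured pair isolates a change like this one, so the expectation rests on compound 3 (at 40100 nM). In this assay the expected change, a 1.3-fold lower number from compound 3 to compound 4 (0.10 log units; within the scatter) by this estimate, stays within the scatter and has no firm direction. The estimate for compound 4 is 32000 nM as a middle value, with an expected range from 14000 nM to 50000 nM overall.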

Compound 4, concentration for 50% growth inhibition: 4400 nM
The estimate for compound 4 lay 7.3-fold (0.86 log units) above the measured number; the whole stated range lies above it.
By their numbers in this assay, from the lowest: compound 4; then compounds 1 and 3 (each within the scatter of the next). At a limit, above all of these: compound 2.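

In this assay, the saturated chain carbon bound to a saturated ring carbon turns out to be a place where the group matters: cyclohexyl in place of propyl brings a 9.1-fold lower number from compound 3 to compound 4 (0.96 log units; beyond the scatter). Within the data shown here, the earlier compounds offered no pair differing in one place, so this is the first change on the shared core that can be read on its own, and it is a step beyond the scatter. Nothing in the data shown accounts for the size of this step.

A single step cannot say whether the gain comes from the ring itself or from the greater number of carbons, a question that a straight hexyl chain at this place would address. It also leaves open whether the gain would survive an amine or a carboxylic acid on the cyclohexyl ring.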